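A few compounds are considered here, and "the series" means these few. Any claim that something is new, unique, unknown or untested is made for them only; others in the source may bear on it.

Compound 2 `COc1ccc(OC)c(Sc2ccc3nnc(Cc4cnn(C)c4)n3n2)c1` sits at the high end of the two numbers available: in an assay on isolated protein for inhibition of Leucine-rich repeat serine/threonine-protein kinase 2 (Homo sapiens), in the presence of a further agent that is not named here (a higher number here means a weaker inhibitor, a lower number a stronger inhibitor), compound 2 gives 32000 nM, while compound 1 `COc1cncc(-c2nnc3ccc(Sc4cc(OC)ccc4OC)nn23)c1` gives 66 nM. Among the measured compounds shown here, the single step between them, a 480-fold higher number from compound 1 to compound 2 (2.69 log units; beyond the scatter), is large and well beyond the scatter. Compound 3 `COc1ccc(OC)c(Sc2ccc3nnc(-c4cn(C)nc4C)n3n2)c1` is built from the same atoms as compound 2, joined differently: 1,3-dimethyl-1H-pyrazol-4-yl in place of (1-methyl-1H-pyrazol-4-yl)methyl on an aromatic carbon. For the measured compounds named here, the only measured step that bears on this change is the one from compound 1 to compound 2, where a 5-methoxypyridin-3-yl on that aromatic carbon gave way to (1-methyl-1H-pyrazol-4-yl)methyl and the number rose steeply. Going by the values given here, compound 3 again carries a ring on that carbon, 1,3-dimethyl-1H-pyrazol-4-yl, so a clear move back toward compound 1 is expected, though the ring is not the one compound 1 carries, so the full return is not taken for granted. Compound 3 is therefore expected to show a 64-fold lower number from compound 2 to compound 3 (1.81 log units; beyond the scatter). Compound 3 is estimated at 500 nM, with a range from 80 nM to 3000 nM.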

Compound 3, half-maximal inhibitory concentration: 323 nM
For compound 3 the middle estimate is 1.5-fold (0.19 log units) above the measured one, within the range that was stated.
By their numbers in this assay, from the lowest: compound 1; then compound 3; then compound 2.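

In this assay, moving from a ring held on a carbon link to a ring attached directly, with the atoms unchanged, gives a 99-fold lower number from compound 2 to compound 3 (2.00 log units; beyond the scatter) and so shows that the large loss at this aromatic carbon does not depend on losing 5-methoxypyridin-3-yl as such. A five-membered ring in that place recovers most of the lost ground, although a 4.9-fold higher number from compound 1 to compound 3 (0.69 log units; beyond the scatter) remains beyond the scatter, so 1,3-dimethyl-1H-pyrazol-4-yl does not fully match 5-methoxypyridin-3-yl. Nothing measured here accounts for either step. As far as these compounds go, the step from compound 2 to compound 3 changes both the attachment and the methyl pattern, so their separate shares remain open, and 1-methyl-1H-pyrazol-4-yl attached directly would bear on this. From the compounds shown here alone, how a plain phenyl ring or a simple amine on that carbon would compare also remains open.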